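Allyl on the amide nitrogen of compound 3

The source may hold more compounds than are shown below. What is called first, only, known or untested is meant among the compounds shown, and "the series" means these compounds.

Measured in an ADME assay on HeLa cells (Homo sapiens) for cytotoxicity, read by resazurin assay, with a stated time of 65 h; a lower number here means that less compound is needed, a higher number that more compound is needed for the effect:
- Compound 1 `O=C(Nc1cccc(C(F)(F)F)c1)c1ccc([N+](=O)[O-])o1`: > 20000 nM
- Compound 2 `COc1ccc(NC(=O)c2ccc([N+](=O)[O-])o2)cc1C(F)(F)F`: > 20000 nM
- Compound 3 `C=CCOc1ccc(NC(=O)c2ccc([N+](=O)[O-])o2)cc1C(F)(F)F`: > 20000 nM

Compound 3 reads > 20000 nM, which is a limit and not a number. The whole set stands at the limit of > 20000 nM in this assay, at which 3 of the 3 values shown sit. Compound 4 `C=CCOc1ccc(N(CC=C)C(=O)c2ccc([N+](=O)[O-])o2)cc1C(F)(F)F` carries allyl in place of hydrogen on an amide-type nitrogen. The closest measured change is a step that the two limits leave unreadable from compound 2 to compound 3, and a step that the two limits leave unreadable from compound 1 to compound 2 and a step that the two limits leave unreadable from compound 1 to compound 3 also give no size. None of these three touches the amide hydrogen. No step beyond the usual scatter is therefore expected in this assay, and no direction can be given. The expected change is a number no higher from compound 3 to compound 4 (the limit leaves the size open). Compound 4 is estimated at 20000 nM, with an expected range from 8000 nM to 40000 nM.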

Compound 4, half-maximal effective concentration: > 20000 nM
Compound 4: a limit, no number; the forecaster's own chance of this, stated with the estimate: 75%; the middle value sits exactly at the limit.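

Compound 3 and compound 4 both give a limit and not a number, so the step between them cannot be read. The compounds shown leave open whether any of these changes shifts the concentration needed in this assay, because all of them stop at the same point: the limit of > 20000 nM in this assay, at which 4 of the 4 values shown sit.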